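Swapping the nitrogen phenyl for cyclohexyl on compound 1

The source may hold more compounds than are shown below. What is called first, only, known or untested is meant among the compounds shown, and "the series" means these compounds.

Measured compounds:
- compound 1, `O=C1COc2ccc(-c3cccc(NS(=O)(=O)c4ccc(F)cc4)c3)cc2N1c1ccccc1`: 30300 nM
- compound 2, `COc1ccc(N2C(=O)COc3ccc(-c4cnc(OC)c(NS(=O)(=O)c5ccc(F)cc5)c4)cc32)cc1`: 13100 nM
- compound 3, `COc1cccc(N2C(=O)COc3ccc(-c4cnc5ccccc5c4)cc32)c1`: 2080 nM

Of the compounds shown here, three sharing a core have been tested in a functional assay on HepG2 cells (Homo sapiens) for antiproliferative activity, read by MTT assay, with a stated time of 72 h; on this read-out lower numbers stand for stronger inhibition and higher numbers for weaker inhibition. Compound 1 gives 30300 nM, the highest of the three numbers, so it is the weakest inhibitor among them. Compound 2 gives 13100 nM, a lower number than compound 1 by more than the usual scatter. Compound 3 gives 2080 nM, the lowest number of the set and well beyond the scatter from compound 1. These three differ from one another in several places at once, so no single change can be read off from them.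

Compound 4, `O=C1COc2ccc(-c3cccc(NS(=O)(=O)c4ccc(F)cc4)c3)cc2N1C1CCCCC1`, has not yet been measured. It differs from compound 1 in one place: cyclohexyl in place of phenyl on an amide-type nitrogen in a ring. Within the data shown here, no measured pair shows what this exchange does on this core, so there is no direct guide to the size or direction of the step. With nothing to point either way, the number for compound 4 in this assay is expected to stay close to that of compound 1, with the step of a 1.1-fold lower number from compound 1 to compound 4 (0.03 log units; within the scatter) estimated as small. Compound 4 is therefore estimated at 28000 nM, with a range from 8000 nM to 90000 nM.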

Compound 4, half-maximal inhibitory concentration: 35900 nM
Beside the measured number, compound 4's estimate is 1.3-fold (0.11 log units) below it, within the range that was stated.
By their numbers in this assay, from the lowest: compound 3; then compound 2; then compounds 1 and 4 (each within the scatter of the next).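

In this assay, cyclohexyl in place of phenyl on the amide-type nitrogen in a ring gives a 1.2-fold higher number from compound 1 to compound 4 (0.07 log units; within the scatter) and so leaves the two compounds indistinguishable. Among these compounds, this is the first direct reading of a single change at this position, which the earlier compounds could not give, as they differ from one another in several places at once: on the core of compound 1, a flat aromatic carbon ring and a non-aromatic carbon ring of equal heavy-atom count read alike on this cell-growth test. No separate measurement is available to explain why this exchange leaves the number where it is.

Going by these compounds, whether this position accepts groups of a different kind remains open, since an amine, a carboxylic acid or a longer chain on this nitrogen could behave quite differently from the two carbon rings compared here. Among the compounds shown here, the exchange has also been read on only one core, so it is unknown whether cyclohexyl would match phenyl in the same way on the cores of compound 2 and compound 3.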